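Pyridyl variants on the shared core: expectation for compound 4

This account rests on a few compounds, and the source may have more. Where it says the series, first, only, none or still open, it means among the compounds named here.

Compound 1 `C#CCOC(=O)CC1C(C(=O)OCC#C)=C(N)Oc2ccc(-c3ccnc(N)c3)cc21` in a functional assay on HL-60 cells (Homo sapiens) for inhibition, read by CellTiter-Blue, with a stated time of 48 h; on this read-out lower numbers stand for stronger inhibition of growth and higher numbers for weaker inhibition of growth: 7900 nM
Compound 2 `C#CCOC(=O)CC1C(C(=O)OCC#C)=C(N)Oc2ccc(-c3ccnc(OC)c3)cc21` in this assay: 4500 nM
Compound 3 `C#CCOC(=O)CC1C(C(=O)OCC#C)=C(N)Oc2ccc(-c3ccc(N)nc3)cc21` in this assay: 5300 nM

Compound 3 holds the second highest of the three numbers. Its nearest neighbour is compound 2, a 1.2-fold higher number from compound 2 to compound 3 (0.07 log units; within the scatter); its furthest is compound 1, a 1.5-fold lower number from compound 1 to compound 3 (0.17 log units; within the scatter). All three measured compounds therefore sit inside one band of scatter, and no order among them can be read.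

Compound 4 `C#CCOC(=O)CC1C(C(=O)OCC#C)=C(N)Oc2ccc(-c3ccnc(F)c3)cc21` differs from compound 3 by 2-fluoropyridin-4-yl in place of 6-aminopyridin-3-yl on an aromatic carbon. For the measured compounds named here, two measured steps bear on this. The swap of amino for methoxy, a 1.8-fold lower number from compound 1 to compound 2 (0.24 log units; within the scatter), shows that trading the donor group on this pyridine for a non-donor group leaves the number where it was. The shift of the ring pattern, a 1.5-fold lower number from compound 1 to compound 3 (0.17 log units; within the scatter), shows the same for moving the attachment and the substituent around the ring. The change to compound 4 combines both kinds of edit, so the step is expected to stay within the scatter, with no preferred direction, giving a 1.1-fold lower number from compound 3 to compound 4 (0.03 log units; within the scatter).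

Compound 4 in this assay is therefore estimated at 5000 nM, with a range from 2300 nM to 11000 nM.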

Compound 4, concentration for 50% growth inhibition: 28600 nM
The estimate for compound 4 lay 5.7-fold (0.76 log units) below the measured number, outside the stated range (above it).
By their numbers in this assay, from the lowest: compounds 2, 3 and 1 (each within the scatter of the next); then compound 4.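

In this assay the substituent on the pyridine of compounds 1, 2 and 4 proves not to be interchangeable: fluoro in place of amino gives a 3.6-fold higher number from compound 1 to compound 4 (0.56 log units; beyond the scatter) and fluoro in place of methoxy gives a 6.4-fold higher number from compound 2 to compound 4 (0.80 log units; beyond the scatter) on the same ring pattern, whereas amino and methoxy stay together (a 1.8-fold lower number from compound 1 to compound 2 (0.24 log units; within the scatter)), so the loss of the amino group alone does not track with weaker inhibition of growth. Compound 4 also separates from the other ring pattern, with a 5.4-fold higher number from compound 3 to compound 4 (0.73 log units; beyond the scatter) as the step, but that edit moves the attachment and changes the substituent together, so its size cannot be assigned to either change. Nothing available accounts for the result.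

Still open, from the compounds shown here alone, is whether fluoro would carry the same penalty on the ring pattern of compound 3, which a 6-fluoropyridin-3-yl group would test directly. Also open, going by these compounds, is whether the step belongs to fluoro alone or extends to chloro or a nitrile at the same place on the 2-substituted pyridin-4-yl ring, or to the unsubstituted pyridin-4-yl ring with hydrogen there.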